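Two Limits and a Trifluoromethyl Swap

A few compounds are considered here, and "the series" means these few. Any claim that something is new, unique, unknown or untested is made for them only; others in the source may bear on it.

Measured compounds:
compound 1, `OC[C@H]1O[C@@H](n2cnc3c(NCc4ccc(Cl)cc4)ncnc32)[C@H](O)[C@@H]1O`: in a functional assay on HOS cells (Homo sapiens) for antiproliferative activity, with a stated time of 72 h (on this read-out higher numbers stand for weaker inhibition and lower numbers for stronger inhibition), compound 1 gives > 166000 nM, a limit of the assay and not a number.
compound 2, `Cc1cccc(CNc2ncnc3c2ncn3[C@@H]2O[C@H](CO)[C@@H](O)[C@H]2O)c1O`: in this assay compound 2 gives > 166000 nM, likewise a limit of the assay.

Going by the values given here, compound 2 therefore stands only at a limit, and the one further value shown for this assay is a limit as well: the limit of > 166000 nM in this assay, at which 2 of the 2 values shown sit. Among the compounds with values here, the single step between the two measured compounds, a step that the two limits leave unreadable from compound 1 to compound 2, is left unreadable by the two limits, so its size and direction are unknown.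

Compound 3, `OC[C@H]1O[C@@H](n2cnc3c(NCc4ccc(C(F)(F)F)cc4)ncnc32)[C@H](O)[C@@H]1O`, differs from compound 2 by a single change: 4-(trifluoromethyl)phenyl in place of 2-hydroxy-3-methylphenyl on a saturated chain carbon bound to a nitrogen on an aromatic ring. Within the data shown here, the only measured step that bears on this change is a step that the two limits leave unreadable from compound 1 to compound 2, and since its size is not readable, it gives no basis for expecting a move in either direction beyond the scatter. The account therefore expects compound 3 to remain at the limit as well, and the step that the limit leaves unreadable from compound 2 to compound 3 is estimated to be negligible.

In this assay compound 3 is estimated at 200000 nM, with a range from 100000 nM to 1000000 nM.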

Compound 3, half-maximal inhibitory concentration: > 166000 nM
Compound 3: no number, only a limit (the forecaster's own chance of this, stated with the estimate: 80%); the middle value does not contradict the limit.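

In this assay compound 3 gives > 166000 nM, a limit of the assay and not a number. No step among compound 1, compound 2 and compound 3 can be read, because all three stand at one limit: the limit of > 166000 nM in this assay, at which 3 of the 3 values shown sit.

The compounds shown leave open whether any of these groups differs from another in this assay, and by how much.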